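The source may report more compounds than this note shows. Statements on the series, on what has been measured and on what is new or still open speak of the compounds shown alone.

The series rests on a shared core carrying an isopropoxycarbonyl group and a methyl group, varied only at one saturated ring carbon. Compound 1 `CC1=C(C(=O)OC(C)C)C(C2CCCC2)N/C(=N/C#N)N1` bears a cyclopentyl group there, compound 2 `CC1=C(C(=O)OC(C)C)C(c2ccsc2)N/C(=N/C#N)N1` a thiophen-3-yl group, and compound 3 `CC1=C(C(=O)OC(C)C)C(c2ccccc2)N/C(=N/C#N)N1` a phenyl group. In an assay on cells for displacement of a labelled ligand from adenosine receptor A1 (Homo sapiens), with a stated time of 60 min, tested at 1 uM (a higher number here means more inhibition at the concentration tested (going by the name of the read-out), a lower number less inhibition), compound 1 gives 3%, compound 2 gives 11%, and compound 3 gives 20%. Compound 3 thus shows the highest number of the three, with a number 9 percentage points higher from compound 2 to compound 3 (within the scatter) lying within the scatter and a number 17 percentage points higher from compound 1 to compound 3 (beyond the scatter) lying beyond it, so that only its distance from compound 1 can be called a real difference.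

Compound 4 `CC1=C(C(=O)OC(C)C)C(c2ccco2)N/C(=N/C#N)N1` continues the variation at the same position: furan-2-yl in place of phenyl on a saturated ring carbon. The step most like this one is the exchange between an aromatic five-membered ring with one hetero atom and phenyl, seen as a number 9 percentage points higher from compound 2 to compound 3 (within the scatter); the other available steps, a number 8 percentage points higher from compound 1 to compound 2 (within the scatter) and a number 17 percentage points higher from compound 1 to compound 3 (beyond the scatter), start from the saturated cyclopentyl group and bear less directly on it. On this basis compound 4 is expected to land near compound 2, with a step of a number 7 percentage points lower from compound 3 to compound 4 (within the scatter) that stays within the scatter. The estimate for compound 4 in this assay is therefore 13%, within a range of 3% to 25%.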

Compound 4, a percentage reported as inhibition, at one concentration (the size of the read-out at that concentration, not a potency): 21%
For compound 4 the middle estimate is 8 percentage points below the measured one, and the stated range covers the measured number.
By their numbers in this assay, from the lowest: compounds 1, 2, 3 and 4 (each within the scatter of the next, the first and the last beyond it).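

At this saturated ring carbon, the read-out in this assay does not separate furan-2-yl from phenyl (a number 1 percentage points higher from compound 3 to compound 4 (within the scatter)), so a five-membered aromatic ring with an oxygen is not told apart here from a six-membered aromatic ring of carbon only. Going by these compounds alone, the two five-membered aromatic rings are not told apart either (a number 10 percentage points higher from compound 2 to compound 4 (within the scatter)), which means that exchanging oxygen-containing furan-2-yl for sulfur-containing thiophen-3-yl gives no step that can be read as real. Furan-2-yl also repeats what phenyl showed against the saturated cyclopentyl group (a number 18 percentage points higher from compound 1 to compound 4 (beyond the scatter)), so two aromatic groups now stand clear of compound 1, while compound 2, with its thiophen-3-yl group, goes against a clean split between aromatic and saturated groups by staying within the scatter of compound 1.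

No measurement shown here accounts for these numbers. From the compounds shown here alone, it remains open whether an aminomethyl group, a carboxylic acid or a longer alkyl chain at this carbon would lift the number clear of compound 4, and whether the isopropoxycarbonyl group or the methyl group on the shared core matters to the read-out at all.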